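The source may report more compounds than this note shows. Statements on the series, on what has been measured and on what is new or still open speak of the compounds shown alone.

For the measured compounds named here, in an ADME assay on MRC5 cells (Homo sapiens) for inhibition, with a stated time of 72 h (on this read-out higher numbers stand for an effect only at larger amounts of compound and lower numbers for an effect already at smaller amounts), compound 2 `COc1cccc(OC)c1C(=O)Nc1c[nH]nc1C(=O)NC1CCC(C)CC1` gives 45000 nM, the only actual number available so far. Compound 1 `COc1cccc(OC)c1C(=O)Nc1c[nH]nc1C(=O)NCCCN(C)C` is reported as > 50000 nM, which is a limit and not a number. Compound 3 `COCCNC(=O)c1n[nH]cc1NC(=O)c1c(OC)cccc1OC` carries 2-methoxyethyl in place of 4-methylcyclohexyl on an amide-type nitrogen. Going by the values given here, the one measured step that bears on this change is at the same nitrogen: an at least 1.1-fold lower number from compound 1 to compound 2 (0.04 log units; that floor lies within the scatter). Among the compounds with values here, with only that small step as a guide, no change beyond the scatter is expected in this assay, although the expected number may well reach the limit of the assay. The estimated change is a 1.1-fold higher number from compound 2 to compound 3 (0.05 log units; within the scatter). For compound 3 the expected value is 50000 nM, with an estimated range from 25000 nM to 100000 nM.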

Compound 3, half-maximal effective concentration: > 50000 nM
Compound 3: a limit, no number; the forecaster's own chance of this, stated with the estimate: 60%; the middle value lies on the limit itself.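

In this assay, putting 2-methoxyethyl in place of 4-methylcyclohexyl on the amide-type nitrogen gives an at least 1.1-fold higher number from compound 2 to compound 3 (0.04 log units; that floor lies within the scatter). For the compounds shown here, compound 3 is reported only at a limit, not as a number, so an open chain ending in methoxy, like the 3-(dimethylamino)propyl chain of compound 1, gives no actual value here, and compound 2 remains the only compound with one. The step from compound 1 to compound 3 cannot be read: the limit of > 50000 nM in this assay, at which 2 of the 3 values shown sit.

As far as these compounds go, how far compound 1 and compound 3 actually lie past the limit stays open. So does what another group on this amide-type nitrogen, such as benzyl, a longer alkyl chain or a carboxylic acid, would give in this assay.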